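Changing the sulfonate aryl group on a weak compound

A few compounds are considered here, and "the series" means these few. Any claim that something is new, unique, unknown or untested is made for them only; others in the source may bear on it.

Compound 1 (`CCc1ccccc1OS(=O)(=O)c1ccc(N2CCN(C)C2=O)cc1`) gives 4600 nM
Compound 2 (`CCN1CCN(c2ccc(S(=O)(=O)Oc3cccc(Cl)c3)cc2)C1=O`) gives 6800 nM
Compound 3 (`CCCN1CCN(c2ccc(S(=O)(=O)Oc3ccccc3CC)cc2)C1=O`) is the third of the series

In a functional assay on HT-29 cells (Homo sapiens) for antiproliferative activity, read by sulforhodamine B assay, with a stated time of 48 h (on this read-out lower numbers stand for stronger inhibition and higher numbers for weaker inhibition), compound 3 gives > 100000 nM as a limit and not as a number. Compound 4 (`CCCN1CCN(c2ccc(S(=O)(=O)Oc3cccc(F)c3)cc2)C1=O`) keeps the chain of compound 3 and carries 3-fluorophenyl in place of 2-ethylphenyl on an oxygen. Among the measured compounds shown here, the only measured step reaching compound 3 is an at least 21-fold higher number from compound 1 to compound 3 (1.33 log units; beyond the scatter) and it concerns the chain, not the group on the oxygen. Compound 4 retains that chain, so the large loss seen in that step is expected to persist. Compound 2 has a shorter chain as well as a different aryl group and gives 6800 nM in this assay without isolating either change. For the measured compounds named here, no measured step tests the exchange on the oxygen alone. A modest move towards a lower number is therefore expected, estimated as an at least 3.3-fold lower number from compound 3 to compound 4 (0.52 log units; beyond the scatter) in this assay and possibly no more than a limit again. For compound 4 the expected value is 30000 nM with an estimated range from 7000 nM to 100000 nM in this assay as the read-out.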

Compound 4, half-maximal inhibitory concentration: 18000 nM
Estimate against measurement, compound 4: 1.7-fold (0.22 log units) above; measured number inside the range.
By their numbers in this assay, from the lowest: compounds 1 and 2 (each within the scatter of the next); then compound 4. At a limit, above all of these: compound 3.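

Among the compounds shown here, compound 4 gives the first measured step at this position, on the oxygen whose other neighbour is the sulfonyl sulfur: in this assay, 3-fluorophenyl in place of 2-ethylphenyl gives an at least 5.5-fold lower number from compound 3 to compound 4 (0.74 log units; beyond the scatter). With the chain of compound 3 held fixed, the exchange on the oxygen alone therefore moves the read-out from a limit to a measured number, which the earlier step, a change of chain only, could not show. The step gives only a minimum size, since the value of compound 3 is a limit and not a number: the limit of > 100000 nM in this assay, at which 1 of the 4 values shown sits.

From the compounds shown here alone, it remains open whether the gain comes from losing the ethyl group or from gaining the fluorine, and whether 3-fluorophenyl would act the same way with the shorter chain of compound 1. Going by these compounds, how an amine or a carboxylic acid on this aryl group would read also stays open.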